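The source may report more compounds than this note shows. Statements on the series, on what has been measured and on what is new or still open speak of the compounds shown alone.

Compound 3 `CNCc1cn(S(=O)(=O)c2ccc(OC)cn2)c(-c2cccnc2F)c1F` in a functional assay on the whole organism (strain Jcl:Sprague-Dawley) for inhibition, with Rattus norvegicus as the target, with stated times of 3 min and 3 h, at a dose of 1 mg/kg by the intravenous route (on this read-out lower numbers stand for less inhibition and higher numbers for more inhibition at the one dose given (going by the name of the read-out)), gives 95%, the second highest of three numbers. Compound 1 `CNCc1cc(-c2cccnc2F)n(S(=O)(=O)c2cccs2)c1` gives 96%, which lies within the scatter of compound 3. Compound 2 `CNCc1cc(-c2cccnc2F)n(S(=O)(=O)c2ccccn2)c1` gives 81%, a gap to compound 3 beyond the scatter. Among the compounds with values here, the one measured step, pyridin-2-yl in place of thiophen-2-yl on a sulfonyl sulfur, gave a number 15 percentage points lower from compound 1 to compound 2 (beyond the scatter), a modest drop. Compound 4 `CNCc1cn(S(=O)(=O)c2cccnc2C)c(-c2cccnc2F)c1F` differs from compound 3 by 2-methylpyridin-3-yl in place of 5-methoxypyridin-2-yl on a sulfonyl sulfur. Within the data shown here, this change sits on the same sulfonyl sulfur as the step from compound 1 to compound 2, but no measured pair swaps one pyridinyl for another there, and no pair varies a methoxy or methyl on that ring, so the single step bears on it only loosely. A small downward step, a number 10 percentage points lower from compound 3 to compound 4 (within the scatter), is expected because the only variation on the sulfonyl sulfur gave a number 15 percentage points lower from compound 1 to compound 2 (beyond the scatter), and the range is set wide. For compound 4 the expected value in this assay is 85%, between 65% and 98%.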

Compound 4, a percentage reported as inhibition, in the whole organism at one dose (the size of the read-out at that dose, not a potency): 92%
Beside the measured number, compound 4's estimate is 7 percentage points below it, within the range that was stated.
By their numbers in this assay, from the lowest: compound 2; then compounds 4, 3 and 1 (each within the scatter of the next).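

In this assay, moving from 5-methoxypyridin-2-yl to 2-methylpyridin-3-yl on a sulfonyl sulfur gave a number 3 percentage points lower from compound 3 to compound 4 (within the scatter), so this swap leaves the read-out unchanged within the scatter at the one dose given. Within the data shown here, the only earlier step at this place, a number 15 percentage points lower from compound 1 to compound 2 (beyond the scatter), exchanged a thiophen-2-yl for a pyridin-2-yl, whereas this is the first step that swaps one pyridinyl group for another, and it shows that this place accepts both of these substituted pyridinyl groups. Nothing available explains this result.

A single-dose percentage is not a potency, so any difference in potency within the pair stays hidden. Also open, from the compounds shown here alone, is how a plain phenyl ring, or a pyridinyl ring carrying a carboxylic acid or a primary amine, would behave on the sulfonyl sulfur.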